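The source may report more compounds than this note shows. Statements on the series, on what has been measured and on what is new or still open speak of the compounds shown alone.

Compound 1 `CN1CCC[C@@H]1Cn1nc(CC2CCCCC2)c2ccccc2c1=O` was tested in an assay for binding affinity to Alpha-1A adrenergic receptor (Homo sapiens); a lower number here means a stronger inhibitor, a higher number a weaker inhibitor. For compound 1 the result is not a number but a limit, > 1990 nM. Compound 2 `CN1CCC[C@@H]1Cn1nc(Cc2ccc(C(C)(C)C)cc2)c2ccccc2c1=O` likewise gives only a limit in this assay, > 1990 nM. Compound 3 `O=c1c2ccccc2c(Cc2ccc(Cl)cc2)nn1C[C@H]1CCCN1CCCCCc1ccc(OCCCN2CCCCCC2)cc1` carries a much larger group than compounds 1 and 2; in this assay compound 3 gives 25.1 nM. The step from compound 1 to compound 4 `COc1cccc(Cc2nn(C[C@H]3CCCN3C)c(=O)c3ccccc23)c1` is 3-methoxyphenyl in place of cyclohexyl on a saturated chain carbon bound to an aromatic carbon. Among the compounds with values here, no measured pair shows this exact change; compound 2 already swaps the cyclohexyl for an aromatic group and still sits at the limit (the limit of > 1990 nM in this assay, at which 2 of the 3 values shown sit). Compound 4 is therefore expected to remain weak, with the step that the limit leaves unreadable from compound 1 to compound 4. The estimate for compound 4 is 3000 nM, within 800 nM to 15000 nM.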

Compound 4, inhibition constant: 1580 nM
Compound 4: middle estimate off by 1.9-fold (0.28 log units), on the high side; the measured number falls inside the stated range.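

With 3-methoxyphenyl in place of cyclohexyl at this position, this assay gives a measured number rather than a limit, and the change reads as an at least 1.2-fold lower number from compound 1 to compound 4 (0.10 log units; that floor lies within the scatter). That step is only a floor, and it cannot establish that 3-methoxyphenyl outperforms cyclohexyl, because the true value of compound 1 stays hidden behind its limit: the limit of > 1990 nM in this assay, at which 2 of the 4 values shown sit.

Plain phenyl at this position would help separate the contribution of the methoxy from that of the aromatic ring. Going by these compounds, whether an amine or a carboxylic acid on the ring would shift the number also remains open.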